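A Methyl Added to the Benzyl Ring of Compound 2

The source may report more compounds than this note shows. Statements on the series, on what has been measured and on what is new or still open speak of the compounds shown alone.

Three related compounds have been tested in a functional assay on NCI-H460 cells (Homo sapiens) for cytotoxicity, read by MTT assay, with a stated time of 2 days; a higher number here means a weaker inhibitor, a lower number a stronger inhibitor. Compound 1 `O=[N+]([O-])c1ccc2c(c1)/C(=N\O)C(c1c[nH]c3ccc([N+](=O)[O-])cc13)=N2` gives 11500 nM, compound 3 `N#Cc1ccc2c(c1)/C(=N\OCc1ccccc1)C(c1c[nH]c3ccc(C#N)cc13)=N2` gives 14500 nM, and compound 2 `c1ccc(CO/N=C2/C(c3c[nH]c4ccccc34)=Nc3ccccc32)cc1` gives 22000 nM. Compound 2 has the highest of the three numbers, yet its gaps to compound 3 and to compound 1 both lie within the usual scatter, so the three cannot be ranked against each other. Compound 4 `Cc1ccc(CO/N=C2/C(c3c[nH]c4ccccc34)=Nc3ccccc32)cc1` differs from compound 2 in one place: methyl in place of hydrogen on an aromatic carbon. Among the compounds with values here, no pair of measured compounds differing in a single place is available to show how large such a step runs. Since only one methyl enters, no step beyond the scatter is expected, and the change from compound 2 to compound 4 is estimated at a 1.1-fold lower number from compound 2 to compound 4 (0.04 log units; within the scatter). Compound 4 is therefore expected to give about 20000 nM, within a range from 8000 nM to 50000 nM.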

Compound 4, half-maximal inhibitory concentration: 29800 nM
Estimate against measurement, compound 4: 1.5-fold (0.17 log units) below; measured number inside the range.
By their numbers in this assay, from the lowest: compounds 1, 3, 2 and 4 (each within the scatter of the next, the first and the last beyond it).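

Within the data shown here, this is the first step between two compounds that differ in one place, and it gives a first measure of such a change: methyl in place of hydrogen on the benzyl ring, para to a large group, gives a 1.4-fold higher number from compound 2 to compound 4 (0.13 log units; within the scatter). At this position, then, benzyl to 4-methylbenzyl produces no difference that can be told from repeat measurement. No available evidence bears on the size of this step.

On these data alone, whether an amine, a carboxylic acid or a longer chain at this place would move the number beyond the scatter stays open. Also open, as far as these compounds go, is whether methyl would read the same elsewhere on this ring or on the benzyl ring of compound 3.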